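A few compounds are considered here, and "the series" means these few. Any claim that something is new, unique, unknown or untested is made for them only; others in the source may bear on it.

Compound 1 `Fc1cc(-c2nc(N3CCN(c4ncccc4C(F)(F)F)CC3)[nH]c2-c2ccc(C(F)(F)F)cc2)cc(F)c1F`: 7 nM in a functional assay on CHO cells for antagonist activity at transient receptor potential cation channel subfamily V member 1 (Rattus norvegicus), read by calcium flux; a higher number here means a weaker inhibitor, a lower number a stronger inhibitor
Compound 2 `Fc1cc(-c2nc(N3CCN(c4ncccc4C(F)(F)F)CC3)[nH]c2-c2cc(F)c(F)c(F)c2)cc(F)c1F`: 44 nM
Compound 3 `C[C@@H]1CN(c2ncc(CO)cc2Cl)CCN1c1nc(-c2cc(F)c(F)c(F)c2)c(-c2ccc(C(F)(F)F)cc2)[nH]1`: 1 nM

Among these three numbers compound 1 stands second highest: compound 2 sits a step above it, a 6.3-fold higher number from compound 1 to compound 2 (0.80 log units; beyond the scatter), and compound 3 lies furthest below it. Compound 4 `COC(=O)c1nc(N2CCN(c3ncccc3C(F)(F)F)CC2)[nH]c1-c1ccc(C(F)(F)F)cc1` differs from compound 1 in one place: methoxycarbonyl in place of 3,4,5-trifluorophenyl on an aromatic carbon. Within the data shown here, no measured step swaps an aromatic ring for a small ester here; the only step touching an aryl group on the shared core is the one from compound 1 to compound 2, which was modest yet beyond the scatter. Replacing a whole ring by a far smaller group is a larger change, so a weaker inhibitor is expected, with a step of about a 29-fold higher number from compound 1 to compound 4 (1.46 log units; beyond the scatter). Compound 4 is therefore estimated at 200 nM, between 30 nM and 2000 nM.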

Compound 4, half-maximal inhibitory concentration: 1170 nM
Compound 4: middle estimate off by 5.9-fold (0.77 log units), on the low side; measured number inside the range.
By their numbers in this assay, from the lowest: compound 3; then compound 1; then compound 2; then compound 4.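

In this assay the change is large, a 170-fold higher number from compound 1 to compound 4 (2.22 log units; beyond the scatter), so methoxycarbonyl does not stand in for 3,4,5-trifluorophenyl at this carbon of the five-membered aromatic ring. Among these compounds, this is the first look at this position, since the earlier step, a 6.3-fold higher number from compound 1 to compound 2 (0.80 log units; beyond the scatter), changed the other aryl group and was smaller. Nothing at hand explains the loss. Still open, on these data alone, is whether the loss goes with removing the ring or with the ester itself. A simple phenyl, a methyl, a carboxylic acid or a primary amide at this carbon would help separate the two.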